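This account rests on a few compounds, and the source may have more. Where it says the series, first, only, none or still open, it means among the compounds named here.

Measured so far:
- compound 1, `Nc1cc(N)c2nc(-c3ccccc3)c(NCc3ccc(Cl)c(Cl)c3)nc2c1`: 27500 nM
- compound 2, `COc1ccc(CNc2nc3cc(N)cc(N)c3nc2-c2ccccc2)cc1OC`: 50100 nM
- compound 3, `Nc1cc(N)c2nc(-c3ccccc3)c(NCc3ccc(F)cc3)nc2c1`: 34700 nM

All three numbers come from a functional assay on A549 cells (Homo sapiens) for inhibition, read by sulforhodamine B assay, with a stated time of 48 h; on this read-out lower numbers stand for stronger inhibition of growth and higher numbers for weaker inhibition of growth. Compound 3 stands second highest of the three; its nearest neighbour is compound 1, a 1.3-fold higher number from compound 1 to compound 3 (0.10 log units; within the scatter), and its furthest is compound 2, a 1.4-fold lower number from compound 2 to compound 3 (0.16 log units; within the scatter). The remaining pair is also close, a 1.8-fold higher number from compound 1 to compound 2 (0.26 log units; within the scatter).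

Compound 4 `COc1ccc(CNc2nc3cc(N)cc(N)c3nc2-c2ccccc2)cc1` differs from compound 3 by methoxy in place of fluoro on an aromatic carbon. The three steps recorded all vary the same aryl group on the benzylic position, and none of them leaves the scatter, so the expected step in this assay is a 1.1-fold higher number from compound 3 to compound 4 (0.04 log units; within the scatter), no clear direction. Compound 4 is therefore estimated at 38000 nM, with a range from 19000 nM to 76000 nM.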

Compound 4, concentration for total growth inhibition: 60300 nM
Compound 4: middle estimate off by 1.6-fold (0.20 log units), on the low side, within the range that was stated.
By their numbers in this assay, from the lowest: compounds 1, 3, 2 and 4 (each within the scatter of the next, the first and the last beyond it).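

In this assay 4-methoxybenzyl in place of 4-fluorobenzyl stays within the scatter (a 1.7-fold higher number from compound 3 to compound 4 (0.24 log units; within the scatter)), and so does hydrogen in place of the second methoxy (a 1.2-fold higher number from compound 2 to compound 4 (0.08 log units; within the scatter)). Among the compounds shown here, the first step at this position to leave the scatter is 4-methoxyphenyl in place of 3,4-dichlorophenyl, and it is only modest (a 2.2-fold higher number from compound 1 to compound 4 (0.34 log units; beyond the scatter)). No evidence on hand bears on these steps.

Every compound shown carries only halogen or methoxy groups on this phenyl ring. As far as these compounds go, whether an amine or a carboxylic acid there, or a longer chain carrying that ring, would give a larger step remains open.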